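A few compounds are considered here, and "the series" means these few. Any claim that something is new, unique, unknown or untested is made for them only; others in the source may bear on it.

Compound 1 `FC(F)(F)c1cccc(NC(=S)Nc2ccccc2)c1`: 49000 nM
Compound 2 `CSCCCNC(=S)Nc1cccc(C(F)(F)F)c1`: > 100000 nM

Both compounds were tested in an ADME assay on MDBK cells (Bos taurus) for cytotoxicity, read by MTT assay, with a stated time of 96 h; on this read-out lower numbers stand for higher toxicity in this test and higher numbers for lower toxicity in this test. Compound 2 stands at the limit of > 100000 nM in this assay, at which 1 of the 2 values shown sits, so its > 100000 nM is a limit of the assay and not a number.

The change to compound 3 `FC(F)(F)c1cccc(NC(=S)Nc2ccccc2Br)c1` is 2-bromophenyl in place of 3-(methylsulfanyl)propyl on an amide-type nitrogen. It puts a six-membered aromatic ring of carbon only back on that nitrogen, where compound 1 carries phenyl. Within the data shown here, the one measured step that bears on this is an at least 2.0-fold higher number from compound 1 to compound 2 (0.30 log units; that floor lies within the scatter). On these data alone, that step is only a floor and lies within the scatter, so its true size stays open. Read in reverse, it points towards a lower number in this assay, with compound 3 expected to land near compound 1 at 49000 nM. The effect of the bromine has not been measured, so the range is kept wide. The expected change is an at least 2.8-fold lower number from compound 2 to compound 3 (0.45 log units; beyond the scatter), towards higher toxicity in this test. Compound 3 is estimated at 35000 nM, with an expected range from 12000 nM to 90000 nM.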

Compound 3, half-maximal cytotoxic concentration: > 100000 nM
Compound 3: no number, only a limit; the forecaster's own chance of this, stated with the estimate: 12%; middle value at least 2.8-fold (0.45 log units) from the limit.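

In this assay, bromo in place of hydrogen on an aromatic carbon gives an at least 2.0-fold higher number from compound 1 to compound 3 (0.30 log units; that floor lies within the scatter), and although that floor lies within the scatter, the bromine brings no shift towards higher toxicity in this test. Compound 3 carries 2-bromophenyl on the amide-type nitrogen, and its > 100000 nM is a limit of the assay and not a number, so an aromatic ring on that nitrogen does not of itself go with a measured number, with compound 1 as the case that goes the other way. The step between compound 2 and compound 3 cannot be read, since both values are limits: the limit of > 100000 nM in this assay, at which 2 of the 3 values shown sit.

On these data alone, how far compound 2 and compound 3 lie past that limit stays open, so the two cannot be placed in order. Also open, as far as these compounds go, is whether a chloro, a methoxy or an amine on the aromatic ring in place of the bromine, or a longer chain on the amide-type nitrogen in place of 3-(methylsulfanyl)propyl, would give a measured number in this assay.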